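Amide nitrogen substituent: cyclohexyl versus 3-ethylphenyl

The source may report more compounds than this note shows. Statements on the series, on what has been measured and on what is new or still open speak of the compounds shown alone.

Three compounds share a core carrying an amide on the same linker; they differ only in the group on the amide nitrogen. In a functional assay on HEK293 cells for agonist activity at D(4) dopamine receptor (Homo sapiens), read by FLIPR (a lower number here means that less compound is needed, a higher number that more compound is needed for the effect), compound 1 `Cc1cc(C)cc(NC(=O)CN2CCC(c3cccc[n+]3[O-])CC2)c1` gives 52 nM, compound 2 `O=C(CN1CCC(c2cccc[n+]2[O-])CC1)NC1CCCCC1` gives 294 nM, and compound 3 `Cc1ccc(Cl)c(NC(=O)CN2CCC(c3cccc[n+]3[O-])CC2)c1Cl` gives 346 nM. Going by the values given here, compound 2 thus stands second highest of the three numbers: its value sits within the scatter of compound 3 and is separated from compound 1 by the one single-point step in the set, a 5.7-fold higher number from compound 1 to compound 2 (0.75 log units; beyond the scatter), which shows that the aromatic substituent in compound 1 needs less compound than the saturated ring in compound 2.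

Compound 4 `CCc1cccc(NC(=O)CN2CCC(c3cccc[n+]3[O-])CC2)c1` has not yet been measured in this assay. Its change from compound 2 is 3-ethylphenyl in place of cyclohexyl on an amide-type nitrogen. The step from compound 1 to compound 2 bears directly on it, since it also exchanges a carbon-only aromatic ring for cyclohexyl at this nitrogen, and ran modestly beyond the scatter. Compound 3 shows that not every aromatic group returns the value of compound 1. A return toward the aromatic end is therefore expected, of roughly the size a 2.9-fold lower number from compound 2 to compound 4 (0.47 log units; beyond the scatter), with a lower number. Compound 4 is estimated at 100 nM, in the range 35 nM to 300 nM.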

Compound 4, half-maximal effective concentration: 95 nM
Estimate against measurement, compound 4: 1.1-fold (0.02 log units) above; the range from low to high includes it.
By their numbers in this assay, from the lowest: compounds 1 and 4 (each within the scatter of the next); then compounds 2 and 3 (each within the scatter of the next).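

In this assay, a second carbon-only aromatic group on the amide-type nitrogen gives a lower number than cyclohexyl (a 3.1-fold lower number from compound 2 to compound 4 (0.49 log units; beyond the scatter)), so the earlier gap to the saturated ring no longer rests on 3,5-dimethylphenyl alone. Exchanging 3,5-dimethylphenyl for 3-ethylphenyl moves the number only within the scatter (a 1.8-fold higher number from compound 1 to compound 4 (0.26 log units; within the scatter)), so two different alkyl patterns on the phenyl ring are not told apart at this nitrogen, and the two groups cannot be ranked. The advantage therefore holds for these two alkyl-substituted phenyl groups only, with the chlorine-bearing aromatic group of compound 3 going against it (346 nM), and no measurement at hand accounts for that exception or for the gap to cyclohexyl.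

The compounds shown leave open whether the unsubstituted phenyl ring already gives numbers like those of compound 1 and compound 4, or whether the alkyl groups are needed. As far as these compounds go, it is also open how far the ring tolerates a longer chain such as butyl in place of ethyl, or a single chlorine, an amine or a carboxylic acid on the ring.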